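Swapping the ring group on a carbonyl carbon

This account rests on a few compounds, and the source may have more. Where it says the series, first, only, none or still open, it means among the compounds named here.

In a functional assay on MV4-11 cells (Homo sapiens) for inhibition, read by luminescence, with a stated time of 3 days (on this read-out higher numbers stand for weaker inhibition of growth and lower numbers for stronger inhibition of growth), compound 1 `CC(C)C1=C(C(=O)N2[C@H](C)CC[C@H]2C(=O)N2CCN(C)CC2)SC2=N[C@@](C)(c3ccc(Cl)cc3)[C@@H](c3ccc(Cl)cc3)N21` gives 190 nM, the higher of two numbers, and compound 2 `CC[C@@H]1CC[C@@H](C(=O)N2CCN(C)CC2)N1C(=O)C1=C(C(C)C)N2C(=N[C@@](C)(c3ccc(Cl)cc3)[C@H]2c2ccc(Cl)cc2)S1` gives 83 nM. In compound 3 `CC(=O)N1CCN(C(=O)[C@@H]2CC[C@@H](C)N2C(=O)C2=C(C(C)C)N3C(=N[C@@](C)(c4ccc(Cl)cc4)[C@H]3c3ccc(Cl)cc3)S2)C[C@H]1C` the change from compound 1 is a group of 10 heavy atoms (7 carbon, 2 nitrogen, 1 oxygen; one six-membered non-aromatic ring with 2 hetero atoms) in place of a group of 7 heavy atoms (5 carbon, 2 nitrogen; one six-membered non-aromatic ring with 2 hetero atoms), on a carbonyl carbon. Among the measured compounds shown here, the one measured step, a 2.3-fold lower number from compound 1 to compound 2 (0.36 log units; beyond the scatter), is modest and comes from methyl in place of hydrogen on a saturated chain carbon, not from a change on the carbonyl carbon, so it offers compound 3 little guidance. No step beyond the scatter is therefore expected, and the estimated step is a 1.2-fold lower number from compound 1 to compound 3 (0.07 log units; within the scatter). For compound 3 the expected value is 160 nM, with an estimated range from 60 nM to 420 nM.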

Compound 3, concentration for 50% growth inhibition: 83 nM
Compound 3: the middle estimate sits 1.9-fold (0.29 log units) above what was measured, within the range that was stated.
By their numbers in this assay, from the lowest: compounds 2 and 3 (each within the scatter of the next); then compound 1.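

The carbonyl carbon is thus a place where the ring group can be changed and the number still moves: in this assay, replacing 4-methylpiperazin-1-yl with the larger ring group of 10 heavy atoms gives a 2.3-fold lower number from compound 1 to compound 3 (0.36 log units; beyond the scatter). Among the compounds shown here, the earlier compounds showed a change only on a saturated chain carbon, so this is the first reading at this position. No measurement on hand explains the step. Which part of the entering group carries the step stays open. So does how a morpholine ring or an open-chain dimethylamino group would read on this carbonyl carbon.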